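The source may report more compounds than this note shows. Statements on the series, on what has been measured and on what is new or still open speak of the compounds shown alone.

Compound 1 `CCOC(=O)c1cccc(NC(=O)N[C@@H](C)c2ccccc2)c1` was tested in an ADME assay on the whole organism with Oryza sativa as the target, tested at 10 uM (on this read-out higher numbers stand for a weaker effect at the one concentration tested and lower numbers for a stronger effect), where compound 1 gives 96%. Compound 3 `CC(=O)c1cccc(NC(=O)N[C@@H](C)c2ccccc2)c1` shares its core; in this assay compound 3 gives 94%. The change between the two is methyl in place of ethoxy on a carbonyl carbon and it made a number 2 percentage points lower from compound 1 to compound 3 (within the scatter). Compound 2 `CCOC(=O)c1ccc(NC(=O)N[C@H](C)c2ccccc2)cc1` carries the same atoms joined differently; how the two cores differ is not broken down here. In this assay compound 2 gives 92%. Compound 4 `CC(=O)c1ccc(NC(=O)N[C@H](C)c2ccccc2)cc1` has not yet been measured in this assay. It differs from compound 2 by methyl in place of ethoxy on a carbonyl carbon, the same change that led from compound 1 to compound 3, at a place described in the same words. Because a number 2 percentage points lower from compound 1 to compound 3 (within the scatter) stayed within the scatter, the expected step is a number 2 percentage points lower from compound 2 to compound 4 (within the scatter). The estimate for compound 4 in this assay is 90%, expected between 82% and 98%.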

Compound 4, a percentage reported as activity, at one concentration (the size of the read-out at that concentration, not a potency): 84%
Estimate against measurement, compound 4: 6 percentage points above; measured number inside the range.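

In this assay, methyl in place of ethoxy on a carbonyl carbon gave a number 8 percentage points lower from compound 2 to compound 4 (within the scatter). Set beside the earlier step, this one does not differ from it by more than such pairs of steps normally do: the same change on two cores in this assay, a number 2 percentage points lower (within the scatter) from compound 1 to compound 3 and a number 8 percentage points lower (within the scatter) from compound 2 to compound 4, 6 percentage points apart, within the scatter of two such steps On these two cores, then, the change carried over without a detectable difference, but neither step stands clear of the scatter, so this shows neither a real effect of the change on either core nor how it would behave on a third.

The compounds shown hold only ethoxy and methyl on that carbonyl carbon. Going by these compounds, what a carboxylic acid, an amine or a longer chain would do at that place remains open.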